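The source may hold more compounds than are shown below. What is called first, only, known or untested is meant among the compounds shown, and "the series" means these compounds.

Measured so far in a functional assay on HepG2 cells (Homo sapiens) for antiproliferative activity, read by MTT assay, with a stated time of 48 h; a higher number here means a weaker inhibitor, a lower number a stronger inhibitor:

- compound 1 `C=CCN1C(=O)C(=O)c2cc(-c3ccc(OC)cc3)ccc21`: 7090 nM
- compound 2 `COc1ccc(-c2ccc3c(c2)C(=O)C(=O)N3Cc2ccc(F)cc2)cc1`: 1120 nM
- compound 3 `COc1ccc(-c2ccc3c(c2)C(=O)C(=O)N3Cc2cccc(OC)c2)cc1`: 700 nM

Compound 2 sits well away from compound 1 and close to compound 3 in this assay: a 6.3-fold lower number from compound 1 to compound 2 (0.80 log units; beyond the scatter); a 1.6-fold lower number from compound 2 to compound 3 (0.20 log units; within the scatter). The number of compound 2 is therefore the second highest of the three shown, though its gap to compound 3 is within the scatter.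

The next compound, compound 4 `COc1ccc(-c2ccc3c(c2)C(=O)C(=O)N3Cc2cc(C)cc(C)c2)cc1`, keeps the shared core and the methoxyphenyl arm of compound 2 and differs only at the group on the saturated chain carbon bound to the amide-type nitrogen in the ring: 3,5-dimethylphenyl in place of 4-fluorophenyl on a saturated chain carbon bound to an amide-type nitrogen in a ring.

Going by the values given here, three steps bear on this. Putting an aryl group in place of vinyl at this position lowers the number clearly: a 6.3-fold lower number from compound 1 to compound 2 (0.80 log units; beyond the scatter) and a 10-fold lower number from compound 1 to compound 3 (1.01 log units; beyond the scatter). Exchanging one aryl group for another at the same position, however, stays within the scatter: a 1.6-fold lower number from compound 2 to compound 3 (0.20 log units; within the scatter). Compound 4 carries an aryl group here as well, so the move from compound 2 is expected to be of the second kind, with no step beyond the scatter in this assay in either direction: a 1.2-fold lower number from compound 2 to compound 4 (0.09 log units; within the scatter).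

For compound 4 in this assay the expected value is 900 nM, with a range from 400 nM to 2000 nM.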

Compound 4, half-maximal inhibitory concentration: 410 nM
Estimate against measurement, compound 4: 2.2-fold (0.34 log units) above, within the range that was stated.
By their numbers in this assay, from the lowest: compounds 4, 3 and 2 (each within the scatter of the next, the first and the last beyond it); then compound 1.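

Going by these compounds alone, exchanging one aryl group for another at this position is not always neutral: in this assay, 3,5-dimethylphenyl in place of 4-fluorophenyl gives a 2.7-fold lower number from compound 2 to compound 4 (0.44 log units; beyond the scatter), the first aryl-for-aryl step beyond the scatter. The aryl groups still do not resolve into a clear order, since 3,5-dimethylphenyl in place of 3-methoxyphenyl gives only a 1.7-fold lower number from compound 3 to compound 4 (0.23 log units; within the scatter), and compound 3 is likewise within the scatter of compound 2, so only compound 2 and compound 4 are separated among the three aryl compounds. The step from vinyl now reaches a 17-fold lower number from compound 1 to compound 4 (1.24 log units; beyond the scatter), but no measurement shown accounts for any of these differences.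

The step to compound 4 removes a fluorine and adds two methyl groups at once, so the shares of the two changes stay unseparated, and an unsubstituted phenyl, 3-methylphenyl or 3,5-difluorophenyl group would be needed to divide them. Also open, from the compounds shown here alone, is how the series responds at this position to a phenethyl group, or to an aryl ring carrying an amine or a carboxylic acid.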